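Trifluoromethoxy in place of bromo on a sulfonyl aryl

The source may report more compounds than this note shows. Statements on the series, on what has been measured and on what is new or still open speak of the compounds shown alone.

Of the compounds shown here, two sharing one core have been tested in a functional assay on HCT-116 cells (Homo sapiens) for antiproliferative activity, read by MTT assay, with a stated time of 72 h; on this read-out lower numbers stand for stronger inhibition and higher numbers for weaker inhibition. Compound 1 `CN(C(=O)c1ccccc1)c1ccc2[nH]c(-c3n[nH]c4ccccc34)cc2n1` gives 10600 nM. Compound 2 `CN(c1ccc2[nH]c(-c3n[nH]c4ccccc34)cc2n1)S(=O)(=O)c1ccc(Br)cc1`, which carries a (4-bromophenyl)sulfonyl in place of benzoyl on a nitrogen on an aromatic ring, gives 9850 nM; the step of a 1.1-fold lower number from compound 1 to compound 2 (0.03 log units; within the scatter) lies within the scatter. Compound 2 thus holds the lower of the two numbers, but not by more than the scatter allows.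

Compound 3 `CN(c1ccc2[nH]c(-c3n[nH]c4ccccc34)cc2n1)S(=O)(=O)c1ccc(OC(F)(F)F)cc1` has not been measured. It differs from compound 2 by trifluoromethoxy in place of bromo on an aromatic carbon. Among the measured compounds shown here, no measured step touches this position, and the only step at hand, from compound 1 to compound 2, was within the scatter. There is therefore no basis in these numbers for expecting a shift beyond the scatter in this assay, and the expected step of a 1.1-fold lower number from compound 2 to compound 3 (0.04 log units; within the scatter) is small. Compound 3 is expected to give about 9000 nM, with a range from 4000 nM to 22000 nM.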

Compound 3, half-maximal inhibitory concentration: 6040 nM
Beside the measured number, compound 3's estimate is 1.5-fold (0.17 log units) above it; low and high end bracket the measured number.
By their numbers in this assay, from the lowest: compounds 3, 2 and 1 (each within the scatter of the next).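

Among the compounds shown here, the change from 4-bromophenyl to 4-(trifluoromethoxy)phenyl gives a 1.6-fold lower number from compound 2 to compound 3 (0.21 log units; within the scatter) in this assay and is the first step read at this aromatic carbon of the sulfonyl aryl. It shows that, among these compounds, trifluoromethoxy with its five heavy atoms can stand in place of bromo here with no shift beyond the scatter. The data shown offer no explanation for the size of this step.

As far as these compounds go, whether an amine, a carboxylic acid or a longer alkoxy chain on this aromatic carbon would move the number beyond the scatter remains open. So does the effect of replacing the methyl on the nitrogen that carries the sulfonyl group with hydrogen or an ethyl group.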